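A few compounds are considered here, and "the series" means these few. Any claim that something is new, unique, unknown or untested is made for them only; others in the source may bear on it.

Measured in a functional assay on HCT-116 cells (Homo sapiens) for antiproliferative activity, read by MTT assay, with a stated time of 48 h; a lower number here means a stronger inhibitor of growth, a higher number a weaker inhibitor of growth
- compound 1 (`CCN(Cc1ccc(C(=O)NO)cc1)c1ncc(-c2ccc(C)cc2)s1`) gives 6870 nM
- compound 2 (`CCCCCCCCN(Cc1ccc(C(=O)NO)cc1)c1ncc(-c2ccc(C)cc2)s1`) gives 6500 nM
- compound 3 (`CCCCCCN(Cc1ccc(C(=O)NO)cc1)c1ncc(-c2ccc(C)cc2)s1`) gives 4850 nM

Compound 3 lies within the scatter of both other compounds (a 1.4-fold lower number from compound 1 to compound 3 (0.15 log units; within the scatter)) and (a 1.3-fold lower number from compound 2 to compound 3 (0.13 log units; within the scatter)). The next structure is compound 4 (`CCCN(Cc1ccc(C(=O)NO)cc1)c1ncc(-c2ccc(C)cc2)s1`), where the change is hexyl to propyl (hydrogen in place of propyl on a saturated chain carbon, three bonds along the chain from a nitrogen on an aromatic ring). The measured chain changes bear directly on this. Compound 1 and compound 2 also differ only within the scatter (a 1.1-fold lower number from compound 1 to compound 2 (0.02 log units; within the scatter)), so no chain change measured so far has moved the number beyond the scatter. In this assay, no step beyond the scatter is therefore expected, and the estimated change is small (a 1.1-fold higher number from compound 3 to compound 4 (0.05 log units; within the scatter)). The expected value for compound 4 is 5500 nM (estimated range 3000 nM to 10000 nM).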

Compound 4, concentration for 50% growth inhibition: 5800 nM
Beside the measured number, compound 4's estimate is 1.1-fold (0.02 log units) below it, within the range that was stated.
By their numbers in this assay, from the lowest: compounds 3, 4, 2 and 1 (each within the scatter of the next).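

At this position in this assay, the propyl chain of compound 4 stays within the scatter of all three other compounds: a 1.2-fold higher number from compound 3 to compound 4 (0.08 log units; within the scatter), a 1.1-fold lower number from compound 2 to compound 4 (0.05 log units; within the scatter) and a 1.2-fold lower number from compound 1 to compound 4 (0.07 log units; within the scatter). With a further chain length added, the ethyl, propyl, hexyl and octyl compounds show no trend with chain length and no preferred length. No supporting evidence bears on this result. Still open, on these data alone, is whether a chain ending in an amine or a carboxylic acid at this position would move the number beyond the scatter.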